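The source may hold more compounds than are shown below. What is called first, only, known or untested is meant among the compounds shown, and "the series" means these compounds.

Measured so far in a functional assay on isolated protein for antagonist activity at C-C chemokine receptor type 9 (Homo sapiens), read by calcium flux, with a stated time of 10 min; a higher number here means a weaker inhibitor, a lower number a stronger inhibitor:

- compound 1 `CC(C)(C)c1ccc(S(=O)(=O)Nc2ccc(Cl)cc2-c2ncccc2CN)cc1`: 3160 nM
- compound 2 `CC(C)(C)c1ccc(S(=O)(=O)Nc2ccc(Cl)cc2-c2nccc(CO)c2O)cc1`: 8.7 nM
- compound 3 `CC(C)(C)c1ccc(S(=O)(=O)Nc2ccc(Cl)cc2-c2nccnc2NCCO)cc1`: 34 nM

Compound 3 stands second highest of the three numbers. Its nearest neighbour is compound 2, the step being a 3.9-fold higher number from compound 2 to compound 3 (0.59 log units; beyond the scatter); its furthest is compound 1, the step being a 93-fold lower number from compound 1 to compound 3 (1.97 log units; beyond the scatter). The remaining measured step, a 360-fold lower number from compound 1 to compound 2 (2.56 log units; beyond the scatter), is of the same kind as the other two: all three exchange the whole ring-bearing group on the aromatic carbon of the shared core.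

Compound 4 `CC(C)(C)c1ccc(S(=O)(=O)Nc2ccc(Cl)cc2-c2nccnc2NCC(=O)O)cc1` differs from compound 3 by carboxy in place of hydroxymethyl on a saturated chain carbon bound to a nitrogen on an aromatic ring. For the measured compounds named here, none of the measured steps touches this chain; each replaces the entire group on the aromatic carbon, and the two that end at compound 3 say nothing about what happens within the (2-hydroxyethyl)amino substituent. The only guidance is that compound 3 sits in the lower part of the range and that the three measured steps are large or modest, so a change of this kind in this assay is taken to be modest at most, with the direction open; a step within the scatter is as plausible as one beyond it.

For compound 4 the expected value in this assay is 60 nM, with a range of 12 nM to 300 nM, which means an expected step of a 1.8-fold higher number from compound 3 to compound 4 (0.25 log units; within the scatter).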

Compound 4, half-maximal inhibitory concentration: 812 nM
Compound 4: the middle estimate sits 14-fold (1.13 log units) below what was measured, and the stated range ends below it.
By their numbers in this assay, from the lowest: compound 2; then compound 3; then compound 4; then compound 1.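

In this assay, for the compounds shown here, this is the first change read inside the (2-hydroxyethyl)amino substituent rather than an exchange of the whole ring-bearing group, and carboxy in place of hydroxymethyl gives a 24-fold higher number from compound 3 to compound 4 (1.38 log units; beyond the scatter). The end of this chain is therefore not a neutral place in the series: a change confined to it is classed as large, as is the exchange of the entire group in a 93-fold lower number from compound 1 to compound 3 (1.97 log units; beyond the scatter). Nothing in the data shown accounts for the step.

From the compounds shown here alone, it remains open whether the step follows from the carboxylic acid as such or from the carbonyl that enters with it; the primary amide, the methyl ester and a longer chain ending in a carboxylic acid would separate these readings. Also unsettled is how much of the value of compound 3, 34 nM, depends on the hydroxyl at all, a question that a plain ethylamino chain or a methoxyethylamino chain would put directly.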